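From trifluoromethoxy to hydroxy in a growth inhibition series

The compounds below may be only part of what the source reports. "The series", "measured", "known", "first", "only" and "open" are said of these compounds alone.

Among the compounds with values here, in a functional assay on DWD cells (Homo sapiens) for inhibition, read by sulforhodamine B assay (on this read-out lower numbers stand for stronger inhibition of growth and higher numbers for weaker inhibition of growth), only two compounds have numbers so far. Compound 1 `Oc1ccc(-c2ccc(-c3ccc(-c4nc5ccccc5[nH]4)cc3)cc2)cc1` gives 46300 nM there. Compound 2 `Oc1cccc2[nH]c(-c3ccc(-c4ccc(-c5ccc(OC(F)(F)F)cc5)cc4)cc3)nc12` gives 3100 nM and so holds the lower of the two numbers, with a gap to compound 1 that lies beyond the usual scatter.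

Compound 3 `Oc1ccc(-c2ccc(-c3ccc(-c4nc5c(O)cccc5[nH]4)cc3)cc2)cc1` is compound 2 with hydrogen in place of trifluoromethyl on an oxygen on an aromatic ring, so that 4-(trifluoromethoxy)phenyl becomes 4-hydroxyphenyl. Within the data shown here, no pair of measured compounds differing in one place is available, so the size of this change has not been seen directly. Among the measured compounds shown here, the only guide is weak: compound 1 is no matched partner, but it also carries 4-hydroxyphenyl and gives 46300 nM on this read-out. A move toward weaker inhibition of growth, beyond the scatter, is therefore expected. The estimated step runs a 3.2-fold higher number from compound 2 to compound 3 (0.51 log units; beyond the scatter) and remains uncertain in size. Compound 3 is expected to read 10000 nM (estimated range 2500 nM to 40000 nM).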

Compound 3, concentration for 50% growth inhibition: 2700 nM
Compound 3: the middle estimate sits 3.7-fold (0.57 log units) above what was measured, within the range that was stated.
By their numbers in this assay, from the lowest: compounds 3 and 2 (each within the scatter of the next); then compound 1.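

With the hydroxy on the core in place, the change from 4-(trifluoromethoxy)phenyl to 4-hydroxyphenyl in this assay is now seen directly, and it gives a 1.1-fold lower number from compound 2 to compound 3 (0.06 log units; within the scatter), so compounds 2 and 3 cannot be told apart on this read-out. Compound 3 also gives the first matched view of the other site of difference: hydroxy in place of hydrogen on an aromatic carbon gives a 17-fold lower number from compound 1 to compound 3 (1.23 log units; beyond the scatter), a large step beyond the scatter. Across these three compounds, the large step therefore belongs to the hydroxy on the core, while the exchange of trifluoromethoxy for hydroxy leaves the number unchanged within the scatter, and no measurement at hand explains either result.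

The compounds shown leave open whether trifluoromethoxy and hydroxy would also read alike on a core without that hydroxy, since each step has been seen only once and in one setting. They also leave open how a methoxy on the core, or an amine or a carboxylic acid in place of the hydroxy on the 4-hydroxyphenyl, would read.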